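Swapping the warhead-bearing ring on a shared pyrazole core

The compounds below may be only part of what the source reports. "The series", "measured", "known", "first", "only" and "open" are said of these compounds alone.

Of the compounds shown here, two built on the same core have been measured in a functional assay on Z-138 cells (Homo sapiens) for inhibition, read by luminescence and CellTiter-Glo, with a stated time of 72 h; on this read-out lower numbers stand for stronger inhibition and higher numbers for weaker inhibition. Compound 1 `O=C(CCl)Nc1ccc(Cn2nc(-c3ccc(Oc4ccccc4)cc3)cc2CO)cc1` gives 400 nM. Compound 2 `C=CC(=O)Nc1cccc(Cn2nc(-c3ccc(Oc4ccccc4)cc3)cc2C(=O)OCC)c1` gives 7800 nM, the higher of the two numbers, a gap well beyond the scatter. Compound 3 `CCOC(=O)c1cc(-c2ccc(Oc3ccccc3)cc2)nn1Cc1ccc(NC(=O)CCl)cc1` differs from compound 2 by one change: 4-(((chloromethyl)carbonyl)amino)phenyl in place of 3-((vinylcarbonyl)amino)phenyl on a saturated chain carbon bound to an aromatic nitrogen. The entering group is the same one that compound 1 carries, and compound 1 gives 400 nM, so a step toward a lower number is expected. The expected step from compound 2 to compound 3 in this assay is a 6.5-fold lower number from compound 2 to compound 3 (0.81 log units; beyond the scatter), though the ester remaining from compound 2 leaves the outcome uncertain. Compound 3 is estimated at 1200 nM, within a range from 350 nM to 4000 nM.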

Compound 3, half-maximal inhibitory concentration: 400 nM
Compound 3: middle estimate off by 3.0-fold (0.48 log units), on the high side; low and high end bracket the measured number.
By their numbers in this assay, from the lowest: compounds 1 and 3 (each within the scatter of the next); then compound 2.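

In this assay, placing 4-(((chloromethyl)carbonyl)amino)phenyl where compound 2 carries 3-((vinylcarbonyl)amino)phenyl gives a 20-fold lower number from compound 2 to compound 3 (1.29 log units; beyond the scatter) (a large step), so this place on a saturated chain carbon bound to an aromatic nitrogen governs the number. By contrast, ethoxycarbonyl in place of hydroxymethyl on an aromatic carbon gives no change at the digits printed from compound 1 to compound 3 (within the scatter) (no measurable effect). Nothing measured here gives a reason for the large step. The swap alters both the reactive group and its ring position, so 4-((vinylcarbonyl)amino)phenyl would be needed to separate the two. Going by these compounds, how a carboxylic acid on that aromatic carbon would read also remains open.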